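This account rests on a few compounds, and the source may have more. Where it says the series, first, only, none or still open, it means among the compounds named here.

Compound 1 `N/C(CC(O)c1cccc2ccccc12)=N\N=C\c1ccc(Cl)c(Cl)c1` gives 16000 nM in an ADME assay on L6 cells (Rattus norvegicus) for cytotoxicity, read by resazurin assay, with a stated time of 72 h; a higher number here means a weaker inhibitor, a lower number a stronger inhibitor. Compound 2 `COc1ccc(/C=N/N=C(\N)CC(O)c2cccc3ccccc23)cc1` gives 6300 nM. Compound 3 `N/C(CC(O)c1cccc2ccccc12)=N\N=C\c1ccccc1` gives 17000 nM.

Compound 3 has the highest number of the three, but its gap to compound 1 lies within the scatter; only compound 2 stands apart, as the step of a 2.7-fold higher number from compound 2 to compound 3 (0.43 log units; beyond the scatter) shows. Compound 4 `N/C(CC(O)c1cccc2ccccc12)=N\N=C\c1cccc(Br)c1` differs from compound 3 by bromo in place of hydrogen on an aromatic carbon. The step that bears on this is a 1.1-fold higher number from compound 1 to compound 3 (0.03 log units; within the scatter), where taking two chlorines off the same ring left the number essentially unchanged. One bromine going onto that ring is therefore expected to make no step beyond the scatter, a 1.1-fold lower number from compound 3 to compound 4 (0.03 log units; within the scatter). For compound 4 the estimate in this assay is 16000 nM, with a range from 8000 nM to 35000 nM.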

Compound 4, half-maximal inhibitory concentration: 3900 nM
For compound 4 the middle estimate is 4.1-fold (0.61 log units) above the measured one; the whole stated range lies above it.
By their numbers in this assay, from the lowest: compounds 4 and 2 (each within the scatter of the next); then compounds 1 and 3 (each within the scatter of the next).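

In this assay, bromo in place of hydrogen, meta to a large group, gives a 4.4-fold lower number from compound 3 to compound 4 (0.64 log units; beyond the scatter), so one added atom on this ring can move the number, although the two chlorines of compound 1 did not. The ring substituents also differ in effect, with a 4.1-fold lower number from compound 1 to compound 4 (0.61 log units; beyond the scatter), while a 1.6-fold lower number from compound 2 to compound 4 (0.21 log units; within the scatter) leaves those two compounds unordered. No measured evidence here explains the bromo step.

Going by these compounds, whether a single chloro, an amine or a carboxylic acid on that same carbon would act like bromo stays open. So does the effect of bromo elsewhere on the ring.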